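This account rests on a few compounds, and the source may have more. Where it says the series, first, only, none or still open, it means among the compounds named here.

Compound 1 `O=C(Nc1nc2ccc(F)cc2s1)N1CCN(c2ccc(Cl)nn2)CC1` marks the starting point in an assay on HEK293 cells for inhibition of transient receptor potential cation channel subfamily V member 1 (Homo sapiens), read by FLIPR (a higher number here means a weaker inhibitor, a lower number a stronger inhibitor), where compound 1 gives > 10000 nM, a limit of the assay rather than a number. Compound 2 `Cc1ccc(N2CCN(C(=O)Nc3ccc(OC(F)(F)F)cc3)CC2)nn1` likewise returns only a limit, > 10000 nM. Compound 3 `Cc1cc(N2CCN(C(=O)Nc3ccc(C(C)C)cc3)CC2)nnc1Cl` also returns a limit, > 10000 nM. Among the compounds with values here, all three measured values therefore sit at the same limit (the limit of > 10000 nM in this assay, at which 3 of the 3 values shown sit), so no step between measured compounds can be sized. Compound 4 `Cc1cc(N2CCN(C(=O)Nc3nc4ccc(F)cc4s3)CC2)nnc1Cl` differs from compound 1 by methyl in place of hydrogen on an aromatic carbon. Within the data shown here, with every measured compound resting at the limit, no step from compound 1 to compound 4 beyond the scatter is expected, and a further limit rather than a number is the likely outcome. Compound 4 is estimated at 15000 nM, with a range of 5000 nM to 50000 nM. The step from compound 1 to compound 4 is expected to be a step that the limit leaves unreadable from compound 1 to compound 4.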

Compound 4, half-maximal inhibitory concentration: > 10000 nM
Compound 4 was reported as a limit (the forecaster's own chance of this, stated with the estimate: 85%); the middle value does not contradict the limit.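

No step can be read from compound 1 to compound 4, because both rest at a limit of the assay: the limit of > 10000 nM in this assay, at which 4 of the 4 values shown sit.

Going by these compounds, whether methyl in place of hydrogen changes anything in this assay stays open, as does which structure on this series would return a number rather than a limit.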